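Swapping the Aromatic Ring for Cyclopentyl on the Alkyne

This account rests on a few compounds, and the source may have more. Where it says the series, first, only, none or still open, it means among the compounds named here.

Of the compounds shown here, three on a shared core have been tested in an assay on cells for inhibition of Indoleamine 2,3-dioxygenase 1 (Homo sapiens); a lower number here means a stronger inhibitor, a higher number a weaker inhibitor. Compound 1 `OC(c1cnc2scc(-c3ccc(Br)cc3)n12)C1CCCCC1` gives 1280 nM. Compound 2 `N#Cc1ccc(NC(=O)NCc2cnc3scc(C#Cc4cccnc4)n23)cc1` gives 3200 nM. Compound 3 `N#Cc1ccc(NC(=O)NCc2cnc3scc(C#Cc4ccsc4)n23)cc1` gives 73.9 nM, the lowest of the three numbers. For the measured compounds named here, only one measured step touches the same position: a 43-fold lower number from compound 2 to compound 3 (1.64 log units; beyond the scatter), which shows that changes on the triple-bonded carbon can shift the number substantially. Compound 4 `N#Cc1ccc(NC(=O)NCc2cnc3scc(C#CC4CCCC4)n23)cc1` differs from compound 3 by cyclopentyl in place of thiophen-3-yl on a triple-bonded carbon. With compound 3 already lowest, a large move is more plausible upward than downward, and a moderate loss is expected: a 3.4-fold higher number from compound 3 to compound 4 (0.53 log units; beyond the scatter). For compound 4 the estimated value in this assay is 250 nM, within a range from 50 nM to 1500 nM.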

Compound 4, half-maximal inhibitory concentration: 418 nM
Estimate against measurement, compound 4: 1.7-fold (0.22 log units) below; low and high end bracket the measured number.
By their numbers in this assay, from the lowest: compound 3; then compound 4; then compound 1; then compound 2.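

In this assay the move to a non-aromatic ring of carbon only on the triple-bonded carbon gives a 5.7-fold higher number from compound 3 to compound 4 (0.75 log units; beyond the scatter) but also a 7.7-fold lower number from compound 2 to compound 4 (0.88 log units; beyond the scatter) and so places cyclopentyl between the two aromatic rings. An aromatic ring on this carbon is thus not needed for a number well below that of compound 2, and compound 2 itself shows that having one does not ensure a low number. Nothing available explains these differences. Going by these compounds, whether an amine or a longer chain such as butyl on the triple-bonded carbon would fall below compound 3 remains open.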